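Cyclopropyl for Methyl on the Amide Nitrogen

The source may hold more compounds than are shown below. What is called first, only, known or untested is meant among the compounds shown, and "the series" means these compounds.

Compound 1 `CNC(=O)/C=C/c1ccncc1-c1ccc2ccccc2c1` was tested in a functional assay on MCF7 cells (Homo sapiens) for inhibition, read by sulforhodamine B assay, with a stated time of 72 h (on this read-out lower numbers stand for stronger inhibition of growth and higher numbers for weaker inhibition of growth), where compound 1 gives 9340 nM. Two other compounds share its core. Compound 3 `CNC(=O)/C=C/c1ccncc1-c1ccc2c(ccn2C)c1` gives 7120 nM in this assay, a number within the usual scatter of that of compound 1, so no order between the two is claimed even though compound 1 holds the higher of the two numbers shown. Compound 2 `Cn1ncc2cc(-c3cnccc3/C=C/C(=O)O)ccc21` reaches only the limit of this assay, > 10000 nM, and no number is known for it. The limit is stated as the limit of > 10000 nM in this assay, at which 1 of the 3 values shown sits.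

Compound 4 `O=C(/C=C/c1ccncc1-c1ccc2ccccc2c1)NC1CC1` has not been measured. It differs from compound 1 in one place: cyclopropyl in place of methyl on an amide-type nitrogen. For the measured compounds named here, no pair of measured compounds differs in this way, so the size of this step is not known from the measured set, and nothing in it supports a move beyond the scatter in either direction. The expected step is a 1.3-fold lower number from compound 1 to compound 4 (0.13 log units; within the scatter), small and within the scatter. For compound 4 the estimate in this assay is 7000 nM, with a range from 2500 nM to 20000 nM.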

Compound 4, concentration for 50% growth inhibition: 6840 nM
Beside the measured number, compound 4's estimate is 1.0-fold (0.01 log units) above it, within the range that was stated.
By their numbers in this assay, from the lowest: compounds 4, 3 and 1 (each within the scatter of the next). At a limit, above all of these: compound 2.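

For the compounds shown here, this is the first measured step at the amide nitrogen: in this assay, cyclopropyl in place of methyl gives a 1.4-fold lower number from compound 1 to compound 4 (0.14 log units; within the scatter) and so the two numbers cannot be told apart. The earlier compounds shown here held methyl at this place or no amide at all, so they could say nothing about a different group on this nitrogen. Now one such exchange has been read, and going from one carbon to three carbons with a three-membered ring on this nitrogen does not separate compound 4 from compound 1 in this read-out. Nothing at hand speaks to why the step is this small.

On these data alone, whether any group on the amide nitrogen can move the number beyond the scatter stays open, for example a longer chain such as n-butyl, a benzyl group, or an ethyl chain ending in an amine. Also open, as far as these compounds go, is whether cyclopropyl in place of methyl on the amide nitrogen of compound 3 would give a step of similar size, since one step on one core cannot show whether the result carries over to another.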